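Moving the nitrile when every value is a limit

A few compounds are considered here, and "the series" means these few. Any claim that something is new, unique, unknown or untested is made for them only; others in the source may bear on it.

Compound 2 `CSCC[C@H](NC(=O)c1ccc(NCc2cncn2Cc2ccc(C#N)cc2)cc1-c1ccccc1)C(=O)O` was tested in a functional assay on NIH3T3 cells (Mus musculus); a higher number here means that more compound is needed for the effect, a lower number that less compound is needed. In this assay compound 2 gives > 10 uM, a limit of the assay rather than a number. Compound 1 `CSCC[C@H](NC(=O)c1ccc(NCc2cncn2Cc2ccccc2C#N)cc1-c1ccccc1)C(=O)O` differs from it by 2-cyanophenyl in place of 4-cyanophenyl on a saturated chain carbon bound to an aromatic nitrogen. In this assay compound 1 gives > 10 uM, again a limit. That change therefore made a step that the two limits leave unreadable from compound 2 to compound 1. Compound 3 `COC(=O)[C@H](CCSC)NC(=O)c1ccc(NCc2cncn2Cc2ccc(C#N)cc2)cc1-c1ccccc1` differs from compound 2 by methyl in place of hydrogen on an oxygen next to a carbonyl group. In this assay compound 3 gives > 10 uM, once more a limit. The step that the two limits leave unreadable from compound 2 to compound 3 is thus unreadable too, as the limit of > 10 uM in this assay, at which 3 of the 3 values shown sit, shows. Compound 4 `COC(=O)[C@H](CCSC)NC(=O)c1ccc(NCc2cncn2Cc2ccccc2C#N)cc1-c1ccccc1` is not yet measured; it differs from compound 3 by 2-cyanophenyl in place of 4-cyanophenyl on a saturated chain carbon bound to an aromatic nitrogen, the same change as between compound 2 and compound 1. The step that the limit leaves unreadable from compound 3 to compound 4 is expected, since the like step that the two limits leave unreadable from compound 2 to compound 1 gave no readable size. Compound 4 is therefore estimated at 30 uM, most likely again only a limit.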

Compound 4, concentration for half-maximal effect: > 10 uM
Compound 4: only a limit was reported; the forecaster's own chance of this, stated with the estimate: 85%; the middle value does not contradict the limit.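

The result for compound 4 is a limit of the assay, so its steps from compound 3 and from compound 1 cannot be read: the limit of > 10 uM in this assay, at which 4 of the 4 values shown sit.

As far as these compounds go, whether either change alters the concentration needed in this assay stays open.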